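A few compounds are considered here, and "the series" means these few. Any claim that something is new, unique, unknown or untested is made for them only; others in the source may bear on it.

Working notes on the series. The shared core of compound 1 `CCCS(=O)(=O)Nc1ccc(F)c(C(=O)c2n[nH]c3ncc(-c4ccccc4OC)cc23)c1F` carries a varying aryl group on an aromatic carbon. In an assay for binding affinity to dual specificity mitogen-activated protein kinase kinase 4 (Homo sapiens), read by KINOMEscan, tested at 100 nM (on this read-out lower numbers stand for a stronger effect and higher numbers for a weaker effect at the one concentration tested), compound 1 gives 1.9%. Compound 2 `CCCS(=O)(=O)Nc1ccc(F)c(C(=O)c2n[nH]c3ncc(-c4ccc(O)cc4)cc23)c1F` gives 0.75%; the change is a number 1.2 percentage points lower from compound 1 to compound 2 (within the scatter). Compound 3 `CCCS(=O)(=O)Nc1ccc(F)c(C(=O)c2n[nH]c3ncc(-c4cccc(N(C)C)c4)cc23)c1F` gives 26%, the highest of the three numbers and thus the weakest effect on this read-out; its separation from compound 1 is a number 24.1 percentage points higher from compound 1 to compound 3 (beyond the scatter) and from compound 2 is a number 25.3 percentage points higher from compound 2 to compound 3 (beyond the scatter).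

Compound 4 `CCCS(=O)(=O)Nc1ccc(F)c(C(=O)c2n[nH]c3ncc(-c4cc(Cl)cc(Cl)c4)cc23)c1F` differs from compound 3 by 3,5-dichlorophenyl in place of 3-(dimethylamino)phenyl on an aromatic carbon. For the measured compounds named here, no measured step involves a 3,5-dichlorophenyl group, so nothing directly predicts this exchange. What bears on it is that the two measured steps ending at compound 3, a number 24.1 percentage points higher from compound 1 to compound 3 (beyond the scatter) and a number 25.3 percentage points higher from compound 2 to compound 3 (beyond the scatter), both rose beyond the scatter, while the other two aryl groups sit within the scatter of each other at low numbers. Removing the 3-(dimethylamino)phenyl group is therefore expected to move the number back down, by a modest amount, though the size is uncertain since the entering group is new to the set. The expected change is a number 16 percentage points lower from compound 3 to compound 4 (beyond the scatter). Compound 4 is estimated at 10%, within 1% to 40%.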

Compound 4, a percentage reported as activity, at one concentration (the size of the read-out at that concentration, not a potency): 73%
For compound 4 the middle estimate is 63 percentage points below the measured one, outside the stated range (above it).
By their numbers in this assay, from the lowest: compounds 2 and 1 (each within the scatter of the next); then compound 3; then compound 4.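

In this assay, the 3,5-dichlorophenyl group of compound 4 gives the weakest effect of the four compounds, with a number 47 percentage points higher from compound 3 to compound 4 (beyond the scatter), a number 72.3 percentage points higher from compound 2 to compound 4 (beyond the scatter) and a number 71.1 percentage points higher from compound 1 to compound 4 (beyond the scatter), all large and beyond the scatter. For the compounds shown here, the position on the aromatic carbon is therefore more sensitive to the choice of aryl group than the earlier compounds showed, and the loss seen with the 3-(dimethylamino)phenyl group is not a ceiling, since leaving that group does not by itself return the number to the low level of the 2-methoxyphenyl and 4-hydroxyphenyl compounds. Nothing available accounts for the size or direction of this change.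

The compounds shown leave open whether the high number belongs to the chlorine atoms themselves or to the way the aryl ring is substituted, and a chlorophenyl group carrying less chlorine, or an unsubstituted phenyl group, would separate these two readings. A methoxyphenyl or hydroxyphenyl group substituted like compound 3 would also show whether the low numbers of compound 1 and compound 2 follow the substituent or its place on the ring.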